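A few compounds are considered here, and "the series" means these few. Any claim that something is new, unique, unknown or untested is made for them only; others in the source may bear on it.

In a functional assay on A549 cells (Homo sapiens) for inhibition, read by MTT assay, with a stated time of 72 h (on this read-out lower numbers stand for stronger inhibition and higher numbers for weaker inhibition), compound 1 (`COC(=O)c1ccc(-c2cn(CCCC(=S)Nc3ccc(C)cc3)nn2)cc1`) reads 50000 nM and compound 2 (`Cc1ccc(NC(=S)CCCn2cc(-c3ccc(C(F)(F)F)cc3)nn2)cc1`) reads 5500 nM, while compound 3 (`COC(=O)c1ccc(-c2cn(CCCC(=S)Nc3ccc(-c4ccccc4)cc3)nn2)cc1`) reads 42300 nM and so stands level with compound 1 within the scatter and clearly higher than compound 2. Compound 4 (`FC(F)(F)c1ccc(-c2cn(CCCC(=S)Nc3ccc(-c4ccccc4)cc3)nn2)cc1`) carries trifluoromethyl in place of methoxycarbonyl on an aromatic carbon, para to a large group (trifluoromethyl in place of methoxycarbonyl on an aromatic carbon). The same exchange was measured once, as a 9.1-fold lower number from compound 1 to compound 2 (0.96 log units; beyond the scatter) on the methyl-bearing compounds. Phenyl in place of methyl, a 1.2-fold lower number from compound 1 to compound 3 (0.07 log units; within the scatter) in size, lies within the scatter, so a modest step to a lower number is expected, resting on that single pair. The expected change is a 9.0-fold lower number from compound 3 to compound 4 (0.95 log units; beyond the scatter) in this assay as an estimate. Compound 4 is estimated at 4700 nM with an expected range of 1800 nM to 13000 nM in that read-out.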

Compound 4, half-maximal inhibitory concentration: 1000 nM
Estimate against measurement, compound 4: 4.7-fold (0.67 log units) above; the whole stated range lies above it.
By their numbers in this assay, from the lowest: compound 4; then compound 2; then compounds 3 and 1 (each within the scatter of the next).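

The trifluoromethyl exchange gives a 42-fold lower number from compound 3 to compound 4 (1.63 log units; beyond the scatter), so its size in this assay depends on whether the core carries methyl or phenyl: the same change on two cores in this assay, a 9.1-fold lower number (0.96 log units; beyond the scatter) from compound 1 to compound 2 and a 42-fold lower number (1.63 log units; beyond the scatter) from compound 3 to compound 4, 4.7-fold (0.67 log units) apart, beyond the scatter of two such steps

Phenyl in place of methyl, level on the methoxycarbonyl compounds, gives a 5.5-fold lower number from compound 2 to compound 4 (0.74 log units; beyond the scatter) on the trifluoromethyl compounds: the same change on two cores in this assay, a 1.2-fold lower number (0.07 log units; within the scatter) from compound 1 to compound 3 and a 5.5-fold lower number (0.74 log units; beyond the scatter) from compound 2 to compound 4, 4.7-fold (0.67 log units) apart, beyond the scatter of two such steps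

The two changes therefore do not add independently in these compounds.

On these data alone, whether this dependence extends to a nitrile or a chlorine in place of trifluoromethyl remains open. So does whether it survives a longer chain or an amide in place of the thioamide.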